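Urea Tail Swap in a Vasopressin V2 Agonist Series

The source may report more compounds than this note shows. Statements on the series, on what has been measured and on what is new or still open speak of the compounds shown alone.

Measured compounds:
compound 1, `O=C(NCc1ccc(C(=O)N2CCCCc3ccccc32)c(Cl)c1)Nc1c(F)cccc1F`, 40 nM
compound 2, `Cc1cc(C(=O)N2CCCCc3ccccc32)cc(C)c1CNC(=O)Nc1c(F)cccc1F`, 82 nM
compound 3, `Cc1cc(C(=O)N2CCCCc3ccccc32)ccc1CNC(=O)NCC(=O)OC(C)(C)C`, 120 nM

Of the compounds shown here, three sharing the same core have been tested in a functional assay on HEK293 cells for agonist activity at Vasopressin V2 receptor (Homo sapiens), read by a luciferase reporter and cAMP accumulation; a lower number here means that less compound is needed, a higher number that more compound is needed for the effect. Compound 3, which carries a urea ending in an ester tail rather than the difluorophenyl group of the other two, stands at the highest of the three numbers. Its nearest neighbour is compound 2, whose number is lower but by an amount that lies within the usual scatter of repeat measurements, so the two cannot be ranked against each other. Compound 1 gives a number lower than that of compound 3 by a margin that is beyond the scatter.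

Compound 4, `Cc1cc(C(=O)N2CCCCc3ccccc32)ccc1CNC(=O)N1CCC[C@H]1C(=O)OC(C)C`, has not yet been measured. It differs from compound 3 in one place: 2-(isopropoxycarbonyl)pyrrolidin-1-yl in place of ((tert-butoxycarbonyl)methyl)amino on a carbonyl carbon. The open chain of the tail is closed into a ring and the hydrogen on the urea nitrogen disappears, while the count of acceptors stays the same. Among the measured compounds shown here, no measured pair in this set isolates such a change, so there is no direct precedent for its size or direction. Given that, the expectation is for a step from compound 3 to compound 4 of a 1.3-fold higher number from compound 3 to compound 4 (0.10 log units; within the scatter) in this assay, which is no more than a modest shift and may well fall within the scatter. For compound 4 the estimated value is therefore 150 nM, with a plausible range from 40 nM to 600 nM.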

Compound 4, half-maximal effective concentration: 950 nM
The estimate for compound 4 lay 6.3-fold (0.80 log units) below the measured number; measured number outside the range, above it.
By their numbers in this assay, from the lowest: compound 1; then compounds 2 and 3 (each within the scatter of the next); then compound 4.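

In this assay, among the compounds shown here, the urea tail proves to be a place where one change can move the number well beyond the scatter: putting 2-(isopropoxycarbonyl)pyrrolidin-1-yl in place of ((tert-butoxycarbonyl)methyl)amino on a carbonyl carbon gives a 7.9-fold higher number from compound 3 to compound 4 (0.90 log units; beyond the scatter) and supplies the first readable step in this set. The earlier compounds shown here could not show this, since no two of them differed in only one place. This single swap, however, bundles several differences: the new five-membered ring, the lost hydrogen-bond donor, the added heavy atoms, the defined stereocentre, and an isopropyl ester instead of a tert-butyl ester, and no supporting measurement says which of them accounts for the step.

The compounds shown leave these differences unseparated: an open chain with a methyl group on the urea nitrogen would remove the urea hydrogen without forming a ring, while a pyrrolidine carrying a tert-butyl ester would form the ring and keep the ester of compound 3. Also open, from the compounds shown here alone, is how a free carboxylic acid in place of the ester, or the mirror-image stereocentre, would read.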